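A few compounds are considered here, and "the series" means these few. Any claim that something is new, unique, unknown or untested is made for them only; others in the source may bear on it.

Of the compounds shown here, three have so far been tested in an assay on HL-60 cells for inhibition of glutathione S-transferase P (Homo sapiens), read by spectrophotometry, tested at 5 uM; a higher number here means more inhibition at the concentration tested (going by the name of the read-out), a lower number less inhibition. Compound 1 `C=C(CC)C(=O)c1ccc(OCc2nc(-c3ccc([N+](=O)[O-])cc3)cs2)c(C)c1C` gives 4.4%. Compound 2 `C=C(CC)C(=O)c1ccc(OCc2nc(-c3ccc4ccccc4c3)cs2)c(C)c1C` gives 0%; it differs from compound 1 in having (naphthalen-2-yl in place of 4-nitrophenyl on an aromatic carbon). That step reads a number 4.4 percentage points lower from compound 1 to compound 2 (within the scatter). Compound 3 `C=C(C)C(=O)c1ccc(OCc2nc(-c3ccc([N+](=O)[O-])cc3)cs2)c(C)c1C` gives 17.2%, the highest of the three numbers; it differs from compound 1 in having (hydrogen in place of methyl on a saturated chain carbon bound to a double-bonded chain carbon). The step here reads a number 12.8 percentage points higher from compound 1 to compound 3 (beyond the scatter).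

Compound 4 `C=C(C)C(=O)c1ccc(OCc2nc(-c3ccc4ccccc4c3)cs2)c(C)c1C` has not yet been measured. It differs from compound 3 by naphthalen-2-yl in place of 4-nitrophenyl on an aromatic carbon, the same change that turns compound 1 into compound 2, now made on the core of compound 3 instead; the two cores differ by hydrogen in place of methyl on a saturated chain carbon bound to a double-bonded chain carbon. The surroundings of the change are the same in both pairs. For the measured compounds named here, the earlier step, a number 4.4 percentage points lower from compound 1 to compound 2 (within the scatter), stayed within the scatter, and no other pair shows how this change behaves, so a similarly small step is expected here, a number 4.2 percentage points lower from compound 3 to compound 4 (within the scatter). Compound 4 is therefore estimated at 13%, most likely between 3% and 24%.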

Compound 4, a percentage reported as inhibition, at one concentration (the size of the read-out at that concentration, not a potency): 11.3%
Compound 4: middle estimate off by 1.7 percentage points, on the high side; low and high end bracket the measured number.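

In this assay, the swap of 4-nitrophenyl for naphthalen-2-yl reads a number 5.9 percentage points lower from compound 3 to compound 4 (within the scatter), and it behaves alike on both cores: the same change on two cores in this assay, a number 4.4 percentage points lower (within the scatter) from compound 1 to compound 2 and a number 5.9 percentage points lower (within the scatter) from compound 3 to compound 4, 1.5 percentage points apart, within the scatter of two such steps. The other change, hydrogen in place of methyl on the saturated chain carbon, reads a number 11.3 percentage points higher from compound 2 to compound 4 (beyond the scatter), and it also carries over from one core to the other: the same change on two cores in this assay, a number 12.8 percentage points higher (beyond the scatter) from compound 1 to compound 3 and a number 11.3 percentage points higher (beyond the scatter) from compound 2 to compound 4, 1.5 percentage points apart, within the scatter of two such steps. This shows that each change transferred between these two closely related cores, but it rests on only four compounds tested at a single concentration, so it says nothing about other cores, other groups or the size of the effect at other concentrations.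

The compounds shown leave open how the number would move with an amine or a carboxylic acid on the aromatic ring in place of the nitro group, or with a longer chain in place of that methyl. They also leave open whether the two changes would still carry over so closely on a core that differs in more than this one place.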